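This account rests on a few compounds, and the source may have more. Where it says the series, first, only, none or still open, it means among the compounds named here.

Measured compounds:
compound 1, `CC(C)(C)c1ccc(CNCCNS(=O)(=O)c2cc(C(F)(F)F)cc(C(F)(F)F)c2)cc1`: 13000 nM
compound 2, `O=S(=O)(NCCCNCc1cccc(Cl)c1)c1cc(C(F)(F)F)cc(C(F)(F)F)c1`: 12000 nM

Both compounds share the core of compound 1 and differ in the chain and in the halogenated benzyl group. In a functional assay on PANC-1 cells (Homo sapiens) for inhibition, read by MTT assay, with a stated time of 72 h (on this read-out lower numbers stand for stronger inhibition of growth and higher numbers for weaker inhibition of growth), compound 2 gives 12000 nM and compound 1 gives 13000 nM; the two numbers lie within the scatter of each other, so neither compound can be set apart from the other on this read-out. Among the measured compounds shown here, no step between measured compounds is available, so nothing is known yet about how a change of the halogen or of its position on the phenyl ring acts in this assay .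

Compound 3, `O=S(=O)(NCCCNCc1ccc(Br)cc1)c1cc(C(F)(F)F)cc(C(F)(F)F)c1`, keeps the chain and core of compound 2 and carries the change (4-bromophenyl in place of 3-chlorophenyl on a saturated chain carbon bound to an amine nitrogen). For the measured compounds named here, with no measured step to lean on, the expected step is none beyond the scatter, in no preferred direction; the expected step of no change at the digits printed from compound 2 to compound 3 (within the scatter) is therefore within the scatter. Compound 3 is expected to give 12000 nM in this assay , with a range from 6000 nM to 25000 nM.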

Compound 3, concentration for 50% growth inhibition: 2200 nM
Estimate against measurement, compound 3: 5.5-fold (0.74 log units) above, outside the stated range (below it).
By their numbers in this assay, from the lowest: compound 3; then compounds 2 and 1 (each within the scatter of the next).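

With the chain and the shared core held constant, 4-bromophenyl in place of 3-chlorophenyl on a saturated chain carbon bound to an amine nitrogen gives a 5.5-fold lower number from compound 2 to compound 3 (0.74 log units; beyond the scatter) in this assay, the first measured sign that the read-out responds to a change at this place. The two groups have the same count of heavy atoms, the same count of hydrogen-bond donors and acceptors, and no net charge, so the step arises without a change in any of these counts, and the difference lies in the halogen and where it sits on the phenyl ring. No available data bear on the reason for this step.

The halogen and its ring position change together in this single step, so the compounds shown cannot assign the step to either one, and 4-chlorophenyl and 3-bromophenyl at the same place would separate the two. Also open, going by these compounds, is whether the step carries over to a longer chain, or whether the 4-bromo group can be replaced by a 4-trifluoromethyl or 4-methoxy group on the same phenyl ring.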